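Series notes: chalcone-pyrazole compounds, one methoxy removed

The compounds below may be only part of what the source reports. "The series", "measured", "known", "first", "only" and "open" are said of these compounds alone.

Measured compounds:
compound 1 `COc1cc(-c2cc(/C=C/C(=O)c3ccc(N)cc3)[nH]n2)cc(OC)c1OC` gives 82%
compound 2 `COc1ccc(-c2cc(/C=C/C(=O)c3ccc(N)cc3)[nH]n2)cc1OC` gives 88%
compound 3 `COc1cc(C(=O)/C=C/c2cc(-c3cc(OC)c(OC)c(OC)c3)n[nH]2)cc(OC)c1OC` gives 100%

All three were tested in a functional assay on SK-OV-3 cells (Homo sapiens) for cytotoxicity, read by sulforhodamine B assay, with a stated time of 48 h, tested at 0.01 uM; a higher number here means a weaker effect of the compound at the concentration tested, a lower number a stronger effect. Compound 3 stands highest of the three, with the others beyond the scatter below it. The difference between the core of compound 3 and the core of compound 1 is not broken down here.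

Within the first pair, the change hydrogen in place of methoxy on an aromatic carbon gave a number 6 percentage points higher from compound 1 to compound 2 (within the scatter).

Compound 4 `COc1ccc(-c2cc(/C=C/C(=O)c3cc(OC)c(OC)c(OC)c3)[nH]n2)cc1OC` is not yet measured. It differs from compound 3 by hydrogen in place of methoxy on an aromatic carbon, the same change as between compound 1 and compound 2. Because compound 3 gives 100% and the earlier step was a number 6 percentage points higher from compound 1 to compound 2 (within the scatter), a step of about a number 1 percentage points lower from compound 3 to compound 4 (within the scatter) is expected. Compound 4 is therefore estimated at 99%, with a likely range from 87% to 108%.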

Compound 4, a percentage reported as activity, at one concentration (the size of the read-out at that concentration, not a potency): 97%
Estimate against measurement, compound 4: 2 percentage points above; low and high end bracket the measured number.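

In this assay, hydrogen in place of methoxy on an aromatic carbon gave a number 3 percentage points lower from compound 3 to compound 4 (within the scatter). Set beside the earlier step, the change reads alike on the two cores: the same change on two cores in this assay, a number 6 percentage points higher (within the scatter) from compound 1 to compound 2 and a number 3 percentage points lower (within the scatter) from compound 3 to compound 4, 9 percentage points apart, within the scatter of two such steps. Both steps lie within the scatter, so neither core shows a clear effect of the change and the two cores show no clear difference, but two cores tested at a single concentration do not establish that the change will behave the same way on other cores in the series.

The compounds shown leave open whether a hydroxyl or a chlorine in place of that methoxy would shift the read-out beyond the scatter. They also leave open how the change behaves at other concentrations.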